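Swapping the Thiophene Ring for a Dimethoxyphenyl Ring

The compounds below may be only part of what the source reports. "The series", "measured", "known", "first", "only" and "open" are said of these compounds alone.

Among the compounds with values here, compound 2 `Cc1cc(O)c(C(C)C)cc1-c1cc(-c2cccs2)c(C#N)c(=O)[nH]1` is the stronger of the two compounds measured so far in a functional assay for inhibition, tested at 40 ug/mL (on this read-out higher numbers stand for a stronger effect at the one concentration tested and lower numbers for a weaker effect), where compound 2 gives 41%. Compound 1 `COc1cccc(-c2cc(-c3cc(C(C)C)c(O)cc3C)[nH]c(=O)c2C#N)c1` gives 30% in the same test. Within the data shown here, the single step between them, a number 11 percentage points higher from compound 1 to compound 2 (beyond the scatter), is the only guide available. Compound 3 `COc1ccc(-c2cc(-c3cc(C(C)C)c(O)cc3C)[nH]c(=O)c2C#N)c(OC)c1` differs from compound 2 in one place: 2,4-dimethoxyphenyl in place of thiophen-2-yl on an aromatic carbon. This change roughly reverses the earlier one: a methoxy-bearing phenyl ring returns where the thiophene ring had replaced such a ring, though now carrying two methoxy groups rather than one. A drop of about the earlier size is therefore expected, so the estimated step is a number 11 percentage points lower from compound 2 to compound 3 (beyond the scatter). For compound 3 the expected value in this assay is 30%, with a likely range from 15% to 45%.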

Compound 3, a percentage reported as inhibition, at one concentration (the size of the read-out at that concentration, not a potency): 37.5%
For compound 3 the middle estimate is 7.5 percentage points below the measured one; low and high end bracket the measured number.
By their numbers in this assay, from the lowest: compounds 1, 3 and 2 (each within the scatter of the next, the first and the last beyond it).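

In this assay, the carbon ortho to a cyano group accepts the 2,4-dimethoxyphenyl group, with 10 heavy atoms against 5 in thiophen-2-yl, with only a number 3.5 percentage points lower from compound 2 to compound 3 (within the scatter). Set against the 3-methoxyphenyl group, the same ring gives a number 7.5 percentage points higher from compound 1 to compound 3 (within the scatter), so compound 3 cannot be told apart from either neighbour, although compound 1 and compound 2 do differ; a methoxy-bearing phenyl ring here therefore does not always go with a number clearly under that of compound 2. No independent data are available to explain these readings.

On these data alone, all three groups at this carbon are aromatic rings, so the effect of an amine, a carboxylic acid or an open alkyl chain there remains open. Also open, as far as these compounds go, is what each methoxy group of compound 3 contributes on its own, and whether these compounds would show a stronger or weaker effect relative to one another at any other concentration, as the readings come from one concentration only.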